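This account rests on a few compounds, and the source may have more. Where it says the series, first, only, none or still open, it means among the compounds named here.

In an ADME assay on Vero cells (Chlorocebus sabaeus) for cytotoxicity, read by CellTiter-Glo, with a stated time of 72 h (on this read-out higher numbers stand for lower toxicity in this test and lower numbers for higher toxicity in this test), compound 1 `[O-][n+]1nc(NC2CCCC2)[n+]([O-])c2ccc(F)cc21` gives 2.3 ug/mL and compound 3 `COCC(C)Nc1n[n+]([O-])c2cc(F)ccc2[n+]1[O-]` gives 6.3 ug/mL. Compound 2 `[O-][n+]1nc(NC2CCCCC2)[n+]([O-])c2ccc(F)cc21` has no exact number: its < 2.5 ug/mL is a limit of the assay. Compound 4 `[O-][n+]1nc(NC2CCCCC2)[n+]([O-])c2ccc(Cl)cc21` has chloro in place of fluoro on an aromatic carbon of compound 2, with the cyclohexyl group kept: chloro in place of fluoro on an aromatic carbon.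

The measured steps do not touch this place. All of them change the group on the nitrogen. Cyclohexyl in place of cyclopentyl gives a step that the limit leaves unreadable from compound 1 to compound 2. With 1-(methoxymethyl)ethyl on the nitrogen, the steps are a 2.7-fold higher number from compound 1 to compound 3 (0.44 log units; beyond the scatter) and an at least 2.5-fold higher number from compound 2 to compound 3 (0.40 log units; beyond the scatter). None of them gives a size for a change of halogen, so no step beyond the scatter is expected in this assay. The expectation rests on compound 2, whose limit is < 2.5 ug/mL. The estimated change is a step that the limit leaves unreadable from compound 2 to compound 4. For compound 4 the expected value is 1.8 ug/mL, with an estimated range of 0.7 ug/mL to 4.5 ug/mL.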

Compound 4, half-maximal cytotoxic concentration: 2.6 ug/mL
Compound 4: middle estimate off by 1.4-fold (0.16 log units), on the low side; the range from low to high includes it.
By their numbers in this assay, from the lowest: compounds 1 and 4 (each within the scatter of the next); then compound 3.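

In this assay, going by these compounds alone, the earlier steps all changed the group on the nitrogen, whereas this one gives a first reading for the halogen on the aromatic carbon: chloro in place of fluoro, with cyclohexyl kept, gives an at least 1.0-fold higher number from compound 2 to compound 4 (0.01 log units; that floor lies within the scatter). Compound 2 has only a limit, so this step is a floor and not a size: the limit of < 2.5 ug/mL in this assay, at which 1 of the 4 values shown sits. With that floor within the scatter, the pair shows no direction for the change. Compound 4 at 2.6 ug/mL gives the cyclohexyl group on the nitrogen its first exact number.

Open, going by these compounds, is whether chloro in place of fluoro reads the same with cyclopentyl or 1-(methoxymethyl)ethyl on the nitrogen. Also open, on these data alone, is how bromo, methoxy or an amine on this aromatic carbon would read.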